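Dimethylamino for Methoxy: Compound 4 in the Assay

The source may hold more compounds than are shown below. What is called first, only, known or untested is meant among the compounds shown, and "the series" means these compounds.

Measured compounds:
compound 1 `COc1ccccc1Nc1nc(-c2ccc(Cl)cc2)c(CC(=O)O)s1`: > 70%
compound 2 `COc1ccc(-c2nc(-c3ccc(OC)cc3)c(CC(=O)O)s2)cc1`: > 70%
compound 3 `COc1ccc(-c2nc(-c3ccc(Br)cc3)c(CC(=O)O)s2)cc1`: > 70%

The three measured compounds were examined in an in vitro functional assay on HEK285-7 cells for antagonist activity at prostaglandin D2 receptor 2 (Homo sapiens), read by BRET and beta-arrestin recruitment; on this read-out lower numbers stand for smaller maximal responses and higher numbers for larger maximal responses. In this assay compound 1 reaches > 70%, which is a limit of the assay rather than a number. Compound 2 likewise reaches > 70%, again a limit. Compound 3 gives > 70%, also a limit. Compound 3 therefore stands at the same limit as the other two values shown, and no ranking among the three can be read; (the limit of > 70% in this assay, at which 3 of the 3 values shown sit).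

Going by the values given here, the single step between measured compounds that differ in one place, a step that the two limits leave unreadable from compound 2 to compound 3, cannot be sized, since both ends of it are limits.

Compound 4 `CN(C)c1ccc(-c2nc(-c3ccc(Br)cc3)c(CC(=O)O)s2)cc1` is not yet measured. It differs from compound 3 by dimethylamino in place of methoxy on an aromatic carbon.

Among the compounds with values here, the only measured step that bears on a change at this position, a step that the two limits leave unreadable from compound 2 to compound 3, offers no readable size, so no shift beyond the scatter is expected from a step that the limit leaves unreadable from compound 3 to compound 4. For compound 4 the estimated value in this assay is 82%, between 70% and 100%, most likely again reported only as the limit.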

Compound 4, largest response reached (reported as efficacy), in percent of the reference or control that the assay uses: > 70%
Compound 4: a limit, no number (the forecaster's own chance of this, stated with the estimate: 80%); the middle value lies beyond the limit too.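

In this assay compound 4 gives > 70%, which is a limit of the assay and not a number. Compound 3 also stands at a limit, so no step can be read between compound 3 and compound 4: the limit of > 70% in this assay, at which 4 of the 4 values shown sit. The compounds shown leave open how large the maximal response of each one is and whether any change on the shared core alters it.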